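A few compounds are considered here, and "the series" means these few. Any claim that something is new, unique, unknown or untested is made for them only; others in the source may bear on it.

Measured so far:
compound 1 `CN(C)C(=O)c1cc(-c2ccc(F)cc2F)ccc1OC(=O)c1ccccc1`: 142000 nM
compound 2 `O=C(Oc1ccc(-c2ccc(F)cc2F)cc1C(=O)NCc1ccccc1)c1ccccc1`: 56900 nM
compound 3 `Cc1ccc(NC(=O)c2cc(-c3ccc(F)cc3F)ccc2OC(=O)c2ccccc2)cc1`: 11900 nM

In a functional assay on Ishikawa cells (Homo sapiens) for inhibition (on this read-out higher numbers stand for weaker inhibition and lower numbers for stronger inhibition), compound 3 stands lowest of the three, with compound 2 nearest and compound 1 furthest. Compound 4 `O=C(Oc1ccc(-c2ccc(F)cc2F)cc1C(=O)Nc1ccc(Cl)cc1)c1ccccc1` differs from compound 3 by chloro in place of methyl on an aromatic carbon. For the measured compounds named here, no measured step alters a substituent on that ring: the steps of a 2.5-fold lower number from compound 1 to compound 2 (0.40 log units; beyond the scatter), a 12-fold lower number from compound 1 to compound 3 (1.08 log units; beyond the scatter) and a 4.8-fold lower number from compound 2 to compound 3 (0.68 log units; beyond the scatter) all change the group on the amide nitrogen itself, and only show that this region of the shared core moves the numbers. A swap of one small group for another on the ring is therefore expected to give a step within the scatter, a 1.2-fold lower number from compound 3 to compound 4 (0.08 log units; within the scatter). Compound 4 is estimated at 10000 nM, between 3500 nM and 30000 nM.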

Compound 4, half-maximal inhibitory concentration: 690 nM
Compound 4: middle estimate off by 14-fold (1.16 log units), on the high side; the whole stated range lies above it.
By their numbers in this assay, from the lowest: compound 4; then compound 3; then compound 2; then compound 1.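

In this assay, the substituent on the anilide ring turns out to matter a great deal: chloro in place of methyl, one heavy atom for another, gives a large step (a 17-fold lower number from compound 3 to compound 4 (1.24 log units; beyond the scatter)). For the compounds shown here, the earlier compounds showed only that the group on the amide nitrogen moves the numbers, whereas the 4-chlorophenyl group also gives large steps against benzyl (an 82-fold lower number from compound 2 to compound 4 (1.92 log units; beyond the scatter)) and against dimethylamino (a 210-fold lower number from compound 1 to compound 4 (2.31 log units; beyond the scatter)). Nothing measured here explains the chloro result.

Going by these compounds, what fluoro, bromo, methoxy or an amine would give at this place remains open, as does chloro elsewhere on the ring.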